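Replacing a Fluorobenzyl Arm with an Alkynyl Pyridinone

A few compounds are considered here, and "the series" means these few. Any claim that something is new, unique, unknown or untested is made for them only; others in the source may bear on it.

Two compounds have been measured in a functional assay on CHO/Galpha16 cells for antagonist activity at prostaglandin E2 receptor EP4 subtype (Homo sapiens), read by calcium flux, with a stated time of 15 min; on this read-out lower numbers stand for stronger inhibition and higher numbers for weaker inhibition:
compound 1 `O=C(O)c1cccc(CNC(=O)c2c(Cc3cccc(C(F)(F)F)c3)sc3c2CCOC3)c1`, which reaches only a limit of the assay, > 1000 nM;
compound 2 `C[C@H](NC(=O)c1c(Cc2cccc(F)c2)sc2c1CCOC2)c1ccc(C(=O)O)cc1`, which gives 5.1 nM.

Compound 2 therefore stands alone as the only numerical result in this assay. The other entry, that of compound 1, is a limit rather than a number: the limit of > 1000 nM in this assay, at which 1 of the 2 values shown sits. Among the measured compounds shown here, no pair of measured compounds differs in a single place, so there is no measured step against which a change can be gauged.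

Compound 3 `C[C@H](NC(=O)c1c(C#Cc2ccc(=O)[nH]c2)sc2c1CCOC2)c1ccc(C(=O)O)cc1` has not yet been measured. It differs from compound 2 at one position: a group of 9 heavy atoms (7 carbon, 1 nitrogen, 1 oxygen; one six-membered aromatic ring with 1 hetero atom) in place of a group of 8 heavy atoms (7 carbon, 1 fluorine; one six-membered aromatic ring of carbon only), on an aromatic carbon.

For the measured compounds named here, with no measured step to lean on, the expectation for compound 3 rests only on the value of compound 2 and on the extent of the change, which swaps the whole 3-fluorobenzyl group for a group of a different kind. The step is expected to go toward weaker inhibition, by a 3.9-fold higher number from compound 2 to compound 3 (0.59 log units; beyond the scatter), somewhat beyond the usual scatter. Compound 3 is accordingly estimated at 20 nM in this assay, within a range from 3 nM to 200 nM.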

Compound 3, half-maximal inhibitory concentration: 642 nM
For compound 3 the middle estimate is 32-fold (1.51 log units) below the measured one; measured number outside the range, above it.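

The step at this position, a 130-fold higher number from compound 2 to compound 3 (2.10 log units; beyond the scatter), shows that in this assay the group on the aromatic carbon next to the ring sulfur cannot be exchanged without a large change in the read-out, even with the rest of the molecule held constant. The heavy-atom counts of the two groups are close, so a similar count alone does not preserve the number: the entering group also differs from 3-fluorobenzyl in its ring, its triple bond, its double bond outside the ring, and its hydrogen-bond donor and acceptor. The compounds shown offer no measurement that explains the size of this step.

This single step changes the link and the ring together, so it leaves open whether the weaker inhibition follows the triple bond, the pyridinone ring or the two in combination. A 3-fluorophenyl ring carried on the same triple bond, or a pyridinone ring carried on a single methylene link, would separate these two parts in this assay.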